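Aryl ketone swap on the shared core: Vero cytotoxicity notes

The source may report more compounds than this note shows. Statements on the series, on what has been measured and on what is new or still open speak of the compounds shown alone.

Measured compounds:
compound 1, `O=C1Oc2ccccc2N/C1=C\C(=O)c1cccs1`: > 1840000 nM
compound 2, `COC(=O)/C=C1\Nc2ccccc2OC1O`: "not determined" (no result reported)

In an ADME assay on Vero cells (Chlorocebus sabaeus) for cytotoxicity, read by MTT assay, with a stated time of 72 h (on this read-out higher numbers stand for lower toxicity in this test and lower numbers for higher toxicity in this test), compound 1 gives only a limit of the assay, not a number: > 1840000 nM. Compound 1 thus sits at the limit of > 1840000 nM in this assay, at which 1 of the 2 values shown sits. Compound 2 has no result in this assay, recorded as "not determined" (no result reported). Compound 3, `Cc1cccc(C(=O)/C=C2\Nc3ccccc3OC2=O)c1`, is still to be measured in this assay. It differs from compound 1 by 3-methylphenyl in place of thiophen-2-yl on a carbonyl carbon. Among the measured compounds shown here, no pair of measured compounds differs in one place, so no step size is known from data. The expectation for the step in this assay is none beyond the usual scatter, since compound 1 rests at the limit of > 1840000 nM in this assay, at which 1 of the 2 values shown sits, and a result at or past that limit is again the likeliest outcome. Compound 3 is therefore estimated at 1840000 nM, within 600000 nM to 5000000 nM. This estimate amounts to an expected step of a number no higher from compound 1 to compound 3 (the limit leaves the size open).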

Compound 3, half-maximal cytotoxic concentration: > 1790000 nM
Compound 3 gave a limit, no number (the forecaster's own chance of this, stated with the estimate: 75%); the middle value is on the limit's open side.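

In this assay, compound 1 and compound 3 both return limits of the assay rather than numbers, so no step can be read between them. The compounds shown leave open where either true value lies, and whether 3-methylphenyl in place of thiophen-2-yl on a carbonyl carbon changes it at all.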